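The compounds below may be only part of what the source reports. "The series", "measured", "known", "first", "only" and "open" are said of these compounds alone.

The measured compounds:
compound 1, `C(=C/c1ccccc1)\C1=NCCN1`, 18.6 nM
compound 2, `c1ccc([C@H]2C[C@@H]2C2=NCCN2)cc1`, 11.8 nM
compound 3, `C[C@@H](CC1=NCCN1)c1ccccc1`, 7240 nM

These numbers come from an assay on PC-12 cells for binding affinity to Nischarin (Rattus norvegicus); a lower number here means a stronger inhibitor, a higher number a weaker inhibitor. Among the three, compound 3 gives the highest number, and its gaps to compound 1 and compound 2 both lie well beyond the scatter, so it is the weakest of the measured set. Within the data shown here, compound 4, `C[C@H](CC1=NCCN1)c1ccccc1`, has not yet been measured. the two compounds have the same atoms and bonds and differ only in configuration as drawn: 1 of 1 stereo elements differ; a stereocentre at a saturated chain carbon is drawn S in compound 3 and R in compound 4 No measured pair in this set differs only in configuration, so the size of such a step here is unknown; pairs of this kind often differ widely, and the weak number for compound 3 leaves room for the other configuration to bind more strongly. A drop in the number, of uncertain size, is expected: a 24-fold lower number from compound 3 to compound 4 (1.38 log units; beyond the scatter). For compound 4 the estimate is 300 nM, with a range from 20 nM to 5000 nM.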

Compound 4, inhibition constant: 589 nM
Estimate against measurement, compound 4: 2.0-fold (0.29 log units) below, within the range that was stated.
By their numbers in this assay, from the lowest: compounds 2 and 1 (each within the scatter of the next); then compound 4; then compound 3.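

Changing only the configuration at this saturated chain carbon gives a 12-fold lower number from compound 3 to compound 4 (1.09 log units; beyond the scatter) in this assay and so provides the first measured size for such a change in this set. The R form as drawn gives the lower number, and the step can be tied to this stereocentre alone because nothing else differs: the fact that compounds 3 and 4 differ only in the configuration as drawn.

Still open, going by these compounds, is whether the R form keeps this advantage when an ethyl group replaces the methyl group on this carbon, or when a longer chain joins this carbon to the shared core.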